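The source may report more compounds than this note shows. Statements on the series, on what has been measured and on what is new or still open speak of the compounds shown alone.

Measured compounds:

Compound 1, `N=C(N)NCCC[C@H](NC(=O)CN(c1nc(Cl)nc2[nH]cnc12)C1CC1)C(=O)OCc1ccccc1`, gives 6.12% in a functional assay on the whole organism (Tail, strain ICR) with Mus musculus as the target, in the tail flick test, with a stated time of 150 min, at a dose of 25 umol/kg by the oral route; a lower number here means a weaker effect, a higher number a stronger effect of the compound at the dose given.
Compound 2, `N=C(N)NCCC[C@H](NC(=O)CN(c1ncnc2c1ncn2C1CCCCO1)C1CC1)C(=O)OCc1ccccc1`, gives 19.6% in this assay.
Compound 3, `CC(C)C[C@H](NC(=O)CN(c1nc(Cl)nc2[nH]cnc12)C1CC1)C(=O)OCc1ccccc1`, gives 5.26% in this assay.

All three share a common build: a glycine-type amide linking an amino-acid ester to a bicyclic heteroaromatic core that also carries a cyclopropyl group. They differ in the core and in the side chain on the amino-acid carbon.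

Compound 1 and compound 3 carry the same core and differ only in that side chain: a group of 3 heavy atoms (3 carbon; no ring) in place of a group of 6 heavy atoms (3 carbon, 3 nitrogen; no ring), on a saturated chain carbon, two bonds along the chain from an amide-type nitrogen and a carbonyl carbon. This change left the read-out almost unchanged, a number 0.9 percentage points lower from compound 1 to compound 3 (within the scatter). Compound 2 has a different core; the difference between the core of compound 1 and the core of compound 2 is not broken down here. Compound 2 stands highest of the three, and its distance to each of the other two lies beyond the scatter.

Compound 4, `CC(C)C[C@H](NC(=O)CN(c1ncnc2c1ncn2C1CCCCO1)C1CC1)C(=O)OCc1ccccc1`, keeps the core of compound 2 and carries the side chain of compound 3. Its difference from compound 2 is a group of 3 heavy atoms (3 carbon; no ring) in place of a group of 6 heavy atoms (3 carbon, 3 nitrogen; no ring), on a saturated chain carbon, two bonds along the chain from an amide-type nitrogen and a carbonyl carbon, the same change, at the same place, that was seen between compound 1 and compound 3. Compound 4 is expected to show a step of a number 1.6 percentage points lower from compound 2 to compound 4 (within the scatter), because the matching step a number 0.9 percentage points lower from compound 1 to compound 3 (within the scatter) stayed within the scatter, though this rests on a single pair with a different core. Compound 4 is therefore estimated at 18% in this assay, expected to lie between 6% and 30%.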

Compound 4, a percentage reported as activity, at one dose (the size of the read-out at that dose, not a potency): 6.47%
Compound 4: the middle estimate sits 11.5 percentage points above what was measured; the range from low to high includes it.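

In this assay, replacing the side chain of compound 2 with isopropyl, at the place where it sits on a saturated chain carbon, gives a step of a number 13.1 percentage points lower from compound 2 to compound 4 (beyond the scatter), so on this core the change is followed by a clear drop in the read-out. Set beside the earlier step, the two cannot be told apart: the same change on two cores in this assay, a number 0.9 percentage points lower (within the scatter) from compound 1 to compound 3 and a number 13.1 percentage points lower (beyond the scatter) from compound 2 to compound 4, 12.3 percentage points apart, within the scatter of two such steps. Among the compounds shown here, this shows that a step lying within the scatter on one core offers no assurance of the same on another, since here the same change lies beyond it on the second core, yet it does not show that the core alters the effect of the change, and equally it does not prove that the effect carries over unchanged, as there are only two pairs, each read at a single dose and a single time.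

Still open, going by these compounds, is how an amine or a carboxylic acid at the end of a chain at this place, or a longer chain there, would behave on either core. Further pairs of this kind, on these two cores and on others, would be needed to tell whether the outcome of this change depends on the core at all.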